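A few compounds are considered here, and "the series" means these few. Any claim that something is new, unique, unknown or untested is made for them only; others in the source may bear on it.

Measured so far in an ADME assay on HEK293 cells (Homo sapiens) for cytotoxicity, read by luminescence, with a stated time of 72 h; a higher number here means that more compound is needed for the effect, a lower number that less compound is needed:
Compound 1 `CCOC(=O)c1c(-c2cccc(OC)c2)[nH]c2cc(F)cc(F)c2c1=O`: > 22000 nM (a limit)
Compound 2 `CCOC(=O)c1c(-c2cccc(Oc3ccccc3)c2)[nH]c2cc(F)cc(F)c2c1=O`: > 22000 nM (a limit)

Compound 2 has no numerical reading in this assay: compound 2 stands at > 22000 nM, which is a limit. Going by the values given here, compound 1 offers no number either, and the series so far amounts to the limit of > 22000 nM in this assay, at which 2 of the 2 values shown sit.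

Compound 3 `CCOC(=O)c1c(-c2cccc(OC(F)(F)F)c2)[nH]c2cc(F)cc(F)c2c1=O` keeps the shared core and changes one group. trifluoromethyl in place of phenyl on an oxygen on an aromatic ring In words, trifluoromethyl takes the place of phenyl on an oxygen on an aromatic ring, so phenoxy becomes trifluoromethoxy.

One measured change falls at the same place: a step that the two limits leave unreadable from compound 1 to compound 2, with phenyl in place of methyl on that oxygen. It gives no measured size, only the observation that neither group brought a number out of the limit. This is thin evidence, resting on compound 1 and compound 2 alone. In this assay the expected change is a number no higher from compound 2 to compound 3 (the limit leaves the size open), so no step beyond the scatter and no direction is expected, and another limit is the likeliest report. For compound 3 the estimated value is 22000 nM, with an expected range of 11000 nM to 44000 nM.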

Compound 3, half-maximal effective concentration: > 22000 nM
Compound 3 ended at the assay's limit; the forecaster's own chance of this, stated with the estimate: 85%; the middle value lies on the limit itself.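

Compound 3 joins compound 1 and compound 2 at a limit of this assay, so no step among these three compounds can be read, and the series still comes down to one line: the limit of > 22000 nM in this assay, at which 3 of the 3 values shown sit.

The compounds shown leave open how methyl, phenyl and trifluoromethyl on an oxygen on an aromatic ring compare, since none of the three gives a number.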